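This account rests on a few compounds, and the source may have more. Where it says the series, first, only, none or still open, it means among the compounds named here.

In a functional assay on HT-29 cells (Homo sapiens) for cytotoxicity, read by XTT assay, with a stated time of 72 h (on this read-out higher numbers stand for weaker inhibition and lower numbers for stronger inhibition), compound 1 (`COc1cc(C(O)c2ccc3c(ccn3C)c2)cc(OC)c1OC`) gives > 1000 nM and this is a limit, not a number. Compound 2 (`CCn1ccc2cc(C(O)c3cc(OC)c(OC)c(OC)c3)ccc21`) gives > 1000 nM and that too is a limit. Compound 3 (`CCn1ccc2cc(/C(=N\O)c3cc(OC)c(OC)c(OC)c3)ccc21`) gives > 1000 nM and that is likewise a limit. Going by the values given here, the series so far has a single mark (the limit of > 1000 nM in this assay, at which 3 of the 3 values shown sit) and compound 3 sits on it without a number of its own.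

Compound 3 goes to compound 4 (`CCn1ccc2cc(/C(=N\N)c3cc(OC)c(OC)c(OC)c3)ccc21`) by amino in place of hydroxy on a double-bonded nitrogen. Among the compounds with values here, only one measured step exists (a step that the two limits leave unreadable from compound 1 to compound 2) and it lies elsewhere, as methyl in place of hydrogen on a saturated chain carbon bound to an aromatic nitrogen. Within the data shown here, it offers no size to carry over, and no measured step touches the double-bonded nitrogen.

With compound 3 at > 1000 nM as a limit, no step beyond the scatter is expected in this assay and no direction can be argued from the data. The expected step is a step that the limit leaves unreadable from compound 3 to compound 4 and it remains only an estimate. For compound 4 the estimated value is 1500 nM with an expected range from 300 nM to 5000 nM and a further report as a limit is the likely outcome.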

Compound 4, half-maximal inhibitory concentration: > 1000 nM
Compound 4: a limit, no number (the forecaster's own chance of this, stated with the estimate: 65%); the middle value does not contradict the limit.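

In this assay the results for compound 3 and compound 4 are both limits, not numbers, and no step can be read between them for amino in place of hydroxy on a double-bonded nitrogen. The compounds shown leave open what number any of them would give and whether any change alters cytotoxicity. The series still has one mark: the limit of > 1000 nM in this assay, at which 4 of the 4 values shown sit.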